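Notes on the fluoro step from compound 2

The source may report more compounds than this note shows. Statements on the series, on what has been measured and on what is new or still open speak of the compounds shown alone.

Measured so far in a functional assay on HEp-2 cells (Homo sapiens) for inhibition; a lower number here means a stronger inhibitor, a higher number a weaker inhibitor

compound 1 `O=C1O/C(=C\Cn2cc(C(F)(F)F)c(=O)[nH]c2=O)C(OCc2ccccc2)=C1OCc1ccccc1` gives 40000 nM
compound 2 `O=C1O/C(=C\Cn2ccc(=O)[nH]c2=O)C(OCc2ccccc2)=C1OCc1ccccc1` gives 40000 nM
compound 3 `O=C1O/C(=C\Cn2cnc3c(-n4cccc4)ncnc32)C(OCc2ccccc2)=C1OCc1ccccc1` gives > 100000 nM ( a limit of the assay, not a number )

Compound 2 stands level with compound 1, its nearest neighbour on the numbers. Compound 3 sits at the limit of > 100000 nM in this assay, at which 1 of the 3 values shown sits. Among the measured compounds shown here, no measured step links compound 3 to the others, so it does not bear on the change considered here.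

Compound 4 `O=C1O/C(=C\Cn2cc(F)c(=O)[nH]c2=O)C(OCc2ccccc2)=C1OCc1ccccc1` has not been measured. It differs from compound 2 by fluoro in place of hydrogen on an aromatic carbon. This is the same aromatic carbon that carries trifluoromethyl in compound 1.

For the measured compounds named here, one measured step bears on this place. Hydrogen in place of trifluoromethyl on that aromatic carbon gives no change at the digits printed from compound 1 to compound 2 (within the scatter). The step is a single pair, so the support is thin, but it gives no reason to expect a shift in either direction. No step beyond the scatter is therefore expected in this assay. The expected size is a 1.1-fold lower number from compound 2 to compound 4 (0.06 log units; within the scatter). For compound 4 the estimated value is 35000 nM, with an expected range of 10000 nM to 80000 nM.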

Compound 4, half-maximal inhibitory concentration: 20000 nM
Beside the measured number, compound 4's estimate is 1.8-fold (0.24 log units) above it; the range from low to high includes it.
By their numbers in this assay, from the lowest: compounds 4, 1 and 2 (each within the scatter of the next). At a limit, above all of these: compound 3.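

In this assay, fluoro in place of hydrogen gives a 2.0-fold lower number from compound 2 to compound 4 (0.30 log units; within the scatter) and fluoro in place of trifluoromethyl gives a 2.0-fold lower number from compound 1 to compound 4 (0.30 log units; within the scatter) on the same aromatic carbon of the series. The earlier reading at this position rested on a single pair, compound 1 and compound 2, whereas a hydrogen atom, a single fluorine and trifluoromethyl can now be compared there, and none of the three steps among them lies beyond the scatter. No measurement shown gives a reason for this flat reading at the position, so it stands as an observation on compound 1, compound 2 and compound 4 only.

The compounds shown leave open whether a group of another kind on this aromatic carbon, such as an amine, a carboxylic acid or a longer chain, would give a step beyond the scatter in this assay. They also leave open whether the same reading would hold if the two benzyloxy groups on the shared core were replaced, as compound 1, compound 2 and compound 4 all carry them.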